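A few compounds are considered here, and "the series" means these few. Any claim that something is new, unique, unknown or untested is made for them only; others in the source may bear on it.

Measured compounds:
compound 1, `Nc1nc(C2CCCO2)nc2sc(Cc3ccccc3)cc12`, gives 2950 nM.
compound 2, `CC(c1ccccc1)c1cc2c(N)nc(-c3cccc(C#N)c3)nc2s1`, gives 1770 nM.

Both numbers come from a functional assay on CHO-K1 cells for antagonist activity at adenosine receptor A1 (Homo sapiens), read by a beta-galactosidase reporter and cAMP accumulation, with stated times of 15 min and 6 h; on this read-out lower numbers stand for stronger inhibition and higher numbers for weaker inhibition. On the numbers shown, compound 1 has the higher of the two, yet compound 2 sits within the scatter of it, so the two cannot be told apart. Compound 3, `Nc1nc(-c2cnccn2)nc2sc(Cc3ccccc3)cc12`, has not yet been measured. It differs from compound 1 in one place: pyrazin-2-yl in place of oxolan-2-yl on an aromatic carbon. Because compound 2 gives 1770 nM with an aromatic ring at the comparable point of the shared core, an aromatic ring entering in compound 3 is not expected to move the number far. He therefore expects a small step of a 1.8-fold lower number from compound 1 to compound 3 (0.27 log units; within the scatter), towards a lower number but not beyond the scatter. His estimate for compound 3 in this assay is 1600 nM, with a range from 400 nM to 6500 nM.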

Compound 3, inhibition constant: 91 nM
Compound 3: middle estimate off by 18-fold (1.25 log units), on the high side; measured number outside the range, below it.
By their numbers in this assay, from the lowest: compound 3; then compounds 2 and 1 (each within the scatter of the next).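

In this assay, putting pyrazin-2-yl in place of oxolan-2-yl on the aromatic carbon between two ring nitrogen atoms gives a 32-fold lower number from compound 1 to compound 3 (1.51 log units; beyond the scatter), a large step beyond the scatter. This shows that the number responds strongly to the group at this position of the shared core, which compounds 1 and 2 could not show, as they differ in more than one place. The change replaces a five-membered non-aromatic ring with a six-membered aromatic ring and also alters the hetero atoms, and nothing measured here explains the step.

The compounds shown leave open which of these differences matters, and whether phenyl or pyridin-2-yl at this position would give a number like that of compound 3. They also leave open how an amine or a longer chain would behave there.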